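The source may report more compounds than this note shows. Statements on the series, on what has been measured and on what is new or still open speak of the compounds shown alone.

In a functional assay on HepG2 cells (Homo sapiens) for antiproliferative activity, read by MTT assay, with a stated time of 72 h (on this read-out lower numbers stand for stronger inhibition and higher numbers for weaker inhibition), compound 1 `NC1=NC2(CCSCC2)N(OCCCOc2ccc(Cl)c(Cl)c2)C(N)=N1` gives 70 nM and compound 3 `NC1=NC2(CCSCC2)N(OCCCOc2ccc(Br)cc2)C(N)=N1` gives 1400 nM. For compound 2 `COc1ccc(OCCCON2C(N)=NC(N)=NC23CCOCC3)cc1` there is no number to start from, as its result reads "not determined" (no result reported). Compound 4 `Cc1cc(C)cc(OCCCON2C(N)=NC(N)=NC23CCOCC3)c1` carries 3,5-dimethylphenyl in place of 4-methoxyphenyl on an oxygen on a saturated carbon. Within the data shown here, the one measured step at this place, a 20-fold higher number from compound 1 to compound 3 (1.30 log units; beyond the scatter), is large, but it exchanges two other groups on the core of compound 1, not on the core of compound 2. With no value for compound 2, no size or direction of step can be expected. The expectation leans only on the span from compound 1 at 70 nM to compound 3 at 1400 nM. In this assay, the estimated value for compound 4 is 300 nM, with an expected range from 60 nM to 1800 nM.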

Compound 4, half-maximal inhibitory concentration: 680 nM
Estimate against measurement, compound 4: 2.3-fold (0.36 log units) below; the range from low to high includes it.
By their numbers in this assay, from the lowest: compound 1; then compound 4; then compound 3.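

No new step can be read from compound 4, since compound 2 has no number to set against it. From the compounds shown here alone, what 3,5-dimethylphenyl in place of 4-methoxyphenyl does on their shared core stays open, and no measured evidence bears on it.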